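The source may hold more compounds than are shown below. What is called first, only, known or untested is meant among the compounds shown, and "the series" means these compounds.

In a functional assay on PC-3 cells (Homo sapiens) for antiproliferative activity, read by MTT assay, with a stated time of 48 h (a lower number here means a stronger inhibitor, a higher number a weaker inhibitor), compound 1 (`COc1ccc(CN(C(=O)CSc2nc3ccccc3s2)c2cc(OC)c(OC)c(OC)c2)cc1N=[N+]=[N-]`) gives 14400 nM and compound 2 (`COc1ccc(CN(C(=O)CSc2nc3ccccc3s2)c2cc(OC)c(OC)c(OC)c2)cc1`) gives 8460 nM. Among the compounds with values here, the only measured step, a 1.7-fold lower number from compound 1 to compound 2 (0.23 log units; within the scatter), puts hydrogen in place of azido on an aromatic carbon, so these numbers cannot separate compound 2 from compound 1. Compound 3 (`COc1cc(N(Cc2ccc(Cl)cc2)C(=O)CSc2nc3ccccc3s2)cc(OC)c1OC`) differs from compound 2 in one place, with chloro in place of methoxy on an aromatic carbon, para to a large group, which turns 4-methoxybenzyl into 4-chlorobenzyl: chloro in place of methoxy on an aromatic carbon. Within the data shown here, no measured step makes this exchange, so the single step from compound 1 is only an indirect guide, and it points to no step beyond the scatter in this assay, in either direction. The estimate therefore means a 1.1-fold higher number from compound 2 to compound 3 (0.03 log units; within the scatter), an expected step within the scatter. For compound 3 the expected value is 9000 nM, with an estimated range from 3500 nM to 23000 nM.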

Compound 3, half-maximal inhibitory concentration: > 80000 nM
Compound 3 was reported as a limit (the forecaster's own chance of this, stated with the estimate: 5%); at least 8.8-fold (0.94 log units) between middle value and limit.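

In this assay, the 4-methoxybenzyl group turns out to be sensitive to change at the place para to a large group, something the azido-to-hydrogen step between compound 1 and compound 2 could not show: swapping methoxy for chloro gives an at least 9.4-fold higher number from compound 2 to compound 3 (0.97 log units; beyond the scatter). Compound 3 also stands apart from the azido-bearing compound, with an at least 5.5-fold higher number from compound 1 to compound 3 (0.74 log units; beyond the scatter), although that step changes the benzyl ring in more than one place. The true size of both steps stays unknown, since compound 3 is reported only as a limit: the limit of > 80000 nM in this assay, at which 1 of the 3 values shown sits.

Only methoxy and chloro appear at this place, so the compounds shown cannot tell whether losing methoxy or gaining chloro matters more. An ethoxy group, a hydroxyl group, an amine or plain hydrogen there would help to separate the two.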